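The source may hold more compounds than are shown below. What is called first, only, known or untested is meant among the compounds shown, and "the series" means these compounds.

Measured so far:
Compound 1, `C=CCn1c(=O)n(Cc2ccccc2)c2nc(N)nc(O)c21`, 25%.
Compound 2, `COc1ccc(Cn2c(=O)n(C3OC(CO)[C@@H](O)[C@H]3O)c3nc(N)nc(O)c32)cc1`, 44%.
Compound 3, `C=CCn1c(=O)n(CCCC)c2nc(N)nc(O)c21`, 77%.

In a functional assay on the whole organism (B cells) with Mus musculus as the target (a lower number here means a smaller maximal response, a higher number a larger maximal response), compound 2 stands second highest of the three. Compound 1 gives 25%. Compound 3 gives 77%. Compound 2 lies between the two, and both gaps are beyond the scatter. The unmeasured compound 4, `[N-]=[N+]=NCC(O)Cn1c(=O)n(C2OC(CO)[C@@H](O)[C@H]2O)c2nc(N)nc(O)c21`, differs from compound 2 in one place: 2-azido-1-hydroxyethyl in place of 4-methoxyphenyl on a saturated chain carbon bound to an aromatic nitrogen. Among the compounds with values here, one measured step bears on this change. It is the step of a number 52 percentage points higher from compound 1 to compound 3 (beyond the scatter), where an aromatic group on a saturated chain carbon bound to an aromatic nitrogen was exchanged for a chain. The change from compound 2 to compound 4 also exchanges an aromatic group for a chain at the same place, though the entering chain carries an azide and a hydroxyl rather than being plain propyl. On this single precedent an increase beyond the scatter is expected, though with considerable uncertainty because only a number 52 percentage points higher from compound 1 to compound 3 (beyond the scatter) is available. Compound 4 is therefore estimated at 60%, within 35% to 85%, an expected step of a number 16 percentage points higher from compound 2 to compound 4 (beyond the scatter).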

Compound 4, largest response reached (reported as maximal response), in percent of the reference or control that the assay uses: 91%
Compound 4: the middle estimate sits 31 percentage points below what was measured; the whole stated range lies below it.
By their numbers in this assay, from the lowest: compound 1; then compound 2; then compound 3; then compound 4.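

In this assay, putting 2-azido-1-hydroxyethyl in place of 4-methoxyphenyl on a saturated chain carbon bound to an aromatic nitrogen gives a number 47 percentage points higher from compound 2 to compound 4 (beyond the scatter) and so a second large rise at this place. Alongside a number 52 percentage points higher from compound 1 to compound 3 (beyond the scatter) in the earlier pair, it shows that the rise on leaving an aromatic group for a chain without a ring also occurs when that chain carries an azide and a hydroxyl, and on a different core. Nothing measured here gives a reason for this rise.

On these data alone, it remains open whether the azide, the hydroxyl or the chain alone accounts for the step, as an amine in place of the azide or a plain butyl chain on the core of compound 4 might show. As far as these compounds go, whether 3-azido-2-hydroxypropyl would act in the same way on the core of compound 1 also stays open.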